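Trimming Isopropyl to Ethyl on Compound 2

The source may report more compounds than this note shows. Statements on the series, on what has been measured and on what is new or still open speak of the compounds shown alone.

Within the data shown here, in an ADME assay on microsomes from liver (Mus musculus) for metabolic stability, read by LC-MS, with a stated time of 10 min, tested at 0.5 uM (on this read-out lower numbers stand for a less stable compound and higher numbers for a more stable compound), compound 1 (`c1ccc2c(c1)CN[C@@H](CN(CC[C@@H]1CCCNC1)[C@H]1CCCc3cccnc31)C2`) gives 23%, while compound 2 (`CC(C)N1CCN(CCCN(C[C@H]2Cc3ccccc3CN2)[C@H]2CCCc3cccnc32)CC1`) gives 58%, the higher of the two numbers measured so far. Compound 3 (`CCN1CCN(CCCN(C[C@H]2Cc3ccccc3CN2)[C@H]2CCCc3cccnc32)CC1`) differs from compound 2 in one place: hydrogen in place of methyl on a saturated chain carbon bound to an amine nitrogen in a ring and a saturated chain carbon. This is hydrogen in place of methyl on a saturated chain carbon bound to an amine nitrogen in a ring and a saturated chain carbon, so isopropyl becomes ethyl. Among the measured compounds shown here, the only measured step is a number 35 percentage points higher from compound 1 to compound 2 (beyond the scatter). It exchanged a whole group, the one carrying the isopropyl, so it gives only a loose guide to a change this small. For the measured compounds named here, no measured pair compares ethyl with isopropyl directly. In this assay, little movement is therefore expected, with a slight lean downward. The expected step is a number 4 percentage points lower from compound 2 to compound 3 (within the scatter). Compound 3 is estimated at 54%, with an expected range from 37% to 70%.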

Compound 3, percent of the compound remaining: 19%
Estimate against measurement, compound 3: 35 percentage points above, and the stated range ends above it.
By their numbers in this assay, from the lowest: compounds 3 and 1 (each within the scatter of the next); then compound 2.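

Losing a single methyl, so that isopropyl becomes ethyl, gives a number 39 percentage points lower from compound 2 to compound 3 (beyond the scatter) in this assay, so one carbon at this place can decide much of the reading. The comparison with the earlier compound is just as telling: exchanging piperidin-3-yl for (4-ethylpiperazin-1-yl)methyl gives a number 4 percentage points lower from compound 1 to compound 3 (within the scatter), which lies within the scatter, so the piperazine with ethyl shows no gain on its own, and the higher number of compound 2 appears only with isopropyl in place. Nothing available explains why this one methyl matters so much.

On these data alone, it remains open how a tert-butyl or a cyclopropyl in place of the isopropyl would read in this assay. It is also unclear whether a plain methyl there would stay as low as the ethyl of compound 3.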